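The source may hold more compounds than are shown below. What is called first, only, known or untested is meant among the compounds shown, and "the series" means these compounds.

Three compounds share one core and differ only in the amine at the end of the chain that hangs from an oxygen on the aromatic ring. Compound 1 `CCN(CC)CCCOc1cc2ncnc(Nc3ccc(C#N)cc3)c2cc1OC` carries a diethylamino group there; in a functional assay on A549 cells (Homo sapiens) for antiproliferative activity, read by MTT assay, with a stated time of 72 h (on this read-out lower numbers stand for stronger inhibition and higher numbers for weaker inhibition), compound 1 gives 50600 nM. Compound 2 `COc1cc2c(Nc3ccc(C#N)cc3)ncnc2cc1OCCCN1CCCC1` carries a pyrrolidin-1-yl group instead, and in this assay compound 2 gives 21800 nM. Compound 3 `COc1cc2c(Nc3ccc(C#N)cc3)ncnc2cc1OCCCN1CCC(C)CC1` carries a 4-methylpiperidin-1-yl group, and in this assay compound 3 gives 32300 nM. On these numbers compound 3 stands second highest of the three; its gap to compound 2 and its gap to compound 1 both lie within the scatter of repeated measurements.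

The steps among them are small. There was a 2.3-fold lower number from compound 1 to compound 2 (0.37 log units; beyond the scatter), a modest shift and the only one beyond the scatter; then a 1.6-fold lower number from compound 1 to compound 3 (0.19 log units; within the scatter) and a 1.5-fold higher number from compound 2 to compound 3 (0.17 log units; within the scatter), both within the scatter.

Compound 4 `COc1cc2c(Nc3ccc(C#N)cc3)ncnc2cc1OCCCN1CCC(c2ccccc2)CC1` differs from compound 3 in one place: phenyl in place of methyl on a saturated ring carbon. Among the compounds with values here, no measured step swaps a group on the saturated ring itself, so nothing here speaks directly to this change; the three amine swaps that were measured moved the number little. The expectation is therefore a 1.3-fold lower number from compound 3 to compound 4 (0.11 log units; within the scatter), a step not clearly beyond the scatter. Compound 4 is estimated at 25000 nM, with a range from 7000 nM to 90000 nM.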

Compound 4, half-maximal inhibitory concentration: 9500 nM
Estimate against measurement, compound 4: 2.6-fold (0.42 log units) above, within the range that was stated.
By their numbers in this assay, from the lowest: compound 4; then compounds 2, 3 and 1 (each within the scatter of the next, the first and the last beyond it).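

Phenyl in place of methyl on a saturated ring carbon, three ring bonds from the ring nitrogen, is the first change here made on the amine ring rather than by swapping the whole amine, and in this assay it gives a 3.4-fold lower number from compound 3 to compound 4 (0.53 log units; beyond the scatter) as a modest but clear shift. Within the data shown here, the 4-phenylpiperidin-1-yl group also stands apart from the two other amines, with a 2.3-fold lower number from compound 2 to compound 4 (0.36 log units; beyond the scatter) and a 5.3-fold lower number from compound 1 to compound 4 (0.73 log units; beyond the scatter) so that compound 4 is the most potent of the four, its step to each of the others lying beyond the scatter, while among the earlier amines only one step did so. The change adds a six-membered aromatic ring of carbon only, but no measurement at hand explains why the number falls with it.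

As far as these compounds go, what stays open is whether the ring must be aromatic or whether any larger group would do, a question that cyclohexyl or benzyl on the same ring carbon could settle. From the compounds shown here alone, it is also open whether a substituted ring such as 4-fluorophenyl, or a longer chain between the oxygen and the amine, would move the number further.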